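This account rests on a few compounds, and the source may have more. Where it says the series, first, only, none or still open, it means among the compounds named here.

Series notes. Compound 1 `O=C(Nc1ccc(Br)cc1)c1csc(Cc2c(Cl)cccc2Cl)n1` and compound 2 `O=C(Nc1ccc(C(F)(F)F)cc1)c1csc(Cc2c(Cl)cccc2Cl)n1` share one core and differ at a single aromatic position. In an assay on CHO cells, read by calcium flux (a higher number here means a weaker inhibitor, a lower number a stronger inhibitor), compound 1 gives 460 nM, and compound 2 gives 88 nM. For the measured compounds named here, the step of a 5.2-fold lower number from compound 1 to compound 2 (0.72 log units; beyond the scatter) is the only one measured so far, and compound 2 stands at the lowest of the two numbers, with compound 1 as its sole neighbour.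

Compound 3 `O=C(Nc1ccc(C(F)(F)F)cc1)c1csc(CCc2c(Cl)cccc2Cl)n1` is not yet measured. Its change from compound 2 is 2,6-dichlorobenzyl in place of 2,6-dichlorophenyl on a saturated chain carbon bound to an aromatic carbon. Going by the values given here, the one measured step, a 5.2-fold lower number from compound 1 to compound 2 (0.72 log units; beyond the scatter), lies at a different place and does not bear on a lengthening of the chain, so there is no measured guide for this change. In the absence of such a guide, the expected step of a 1.7-fold higher number from compound 2 to compound 3 (0.23 log units; within the scatter) is set at none beyond the scatter, with a wide range to match. Compound 3 is thus expected to give 150 nM in this assay, between 40 nM and 600 nM.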

Compound 3, half-maximal inhibitory concentration: > 4000 nM
Compound 3 gave a limit, no number; the forecaster's own chance of this, stated with the estimate: 5%; middle value at least 26-fold (1.42 log units) away from the limit.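

The chain carbon bound to the aromatic carbon proves a sensitive place in the series: 2,6-dichlorobenzyl in place of 2,6-dichlorophenyl gives an at least 45-fold higher number from compound 2 to compound 3 (1.65 log units; beyond the scatter). For the compounds shown here, this change moves the number further than the only earlier change, trifluoromethyl in place of bromo, which gave a 5.2-fold lower number from compound 1 to compound 2 (0.72 log units; beyond the scatter). In this assay, compound 3 gives a limit and not a number: the limit of > 4000 nM in this assay, at which 1 of the 3 values shown sits.

The compounds shown leave open whether a longer chain, or an amine or ether oxygen placed in the chain, would stay at this limit or return towards the value of compound 2. From the compounds shown here alone, it is also open whether 2,6-dichlorobenzyl has the same outcome with bromo in place of trifluoromethyl, as the chain change is seen with trifluoromethyl only.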